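Ester in place of amide on the acrylonitrile carbonyl

The compounds below may be only part of what the source reports. "The series", "measured", "known", "first", "only" and "open" are said of these compounds alone.

Within the data shown here, compound 2 `N#C/C(=C\c1c(-c2ccccc2)[nH]c2ccccc12)C(=O)N1CCCCC1` carries the highest number of the two measured so far: in a functional assay on MT4 cells (Homo sapiens) for antiproliferative activity, read by MTT assay, with a stated time of 96 h (on this read-out lower numbers stand for an effect already at smaller amounts and higher numbers for an effect only at larger amounts of compound), compound 2 gives 9600 nM, whereas compound 1 `COc1ccc2[nH]c(-c3ccccc3)c(C=C(C#N)C#N)c2c1` gives 1000 nM; these two differ at more than one place, so only what the two values show is noted. Compound 3 `COCCOC(=O)/C(C#N)=C/c1c(-c2ccccc2)[nH]c2ccccc12` is not yet measured. It arises from compound 2 by 2-methoxyethoxy in place of piperidin-1-yl on a carbonyl carbon. Among the measured compounds shown here, no single-place step between measured compounds is available; a moderate move toward a lower number is expected, possibly exceeding the scatter. The expected step reads a 2.4-fold lower number from compound 2 to compound 3 (0.38 log units; beyond the scatter). Compound 3 is estimated at 4000 nM, within 1000 nM to 15000 nM.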

Compound 3, half-maximal effective concentration: 1200 nM
Beside the measured number, compound 3's estimate is 3.3-fold (0.52 log units) above it; the measured number falls inside the stated range.
By their numbers in this assay, from the lowest: compounds 1 and 3 (each within the scatter of the next); then compound 2.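

In this assay, among these compounds, the carbonyl carbon proves sensitive to what it carries: 2-methoxyethoxy in place of piperidin-1-yl gives an 8.0-fold lower number from compound 2 to compound 3 (0.90 log units; beyond the scatter) and provides the first single-place reading. The change replaces an amide with an ester and a ring with an open chain in one move, so the step cannot be assigned to either feature. No measurement on hand offers an explanation for the step.

Still open, as far as these compounds go, is whether the chain's ether oxygen matters, a question for a plain butyl ester. Whether any amide behaves like compound 2 remains a question for a morpholine amide or a dimethylamide.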